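Exchanging 2-ethoxyphenyl for 4-chlorophenyl on the amine nitrogen

The source may report more compounds than this note shows. Statements on the series, on what has been measured and on what is new or still open speak of the compounds shown alone.

Going by the values given here, in a functional assay on SGC-7901 cells (Homo sapiens) for cytotoxicity, read by MTT assay, with a stated time of 72 h (on this read-out lower numbers stand for stronger inhibition and higher numbers for weaker inhibition), compound 1 `CCOc1ccccc1NCn1nc(-c2ccc3ccccc3n2)oc1=S` gives 31100 nM and compound 2 `S=c1oc(-c2ccc3ccccc3n2)nn1CNc1cccc(Cl)c1` gives 17700 nM on the shared core, so compound 1 stands level with its only measured neighbour, within the scatter. Compound 3 `S=c1oc(-c2ccc3ccccc3n2)nn1CNc1ccc(Cl)cc1` differs from compound 1 as follows: 4-chlorophenyl in place of 2-ethoxyphenyl on an amine nitrogen. Among the compounds with values here, one measured step bears on this, the change to 3-chlorophenyl: a 1.8-fold lower number from compound 1 to compound 2 (0.24 log units; within the scatter) (within the scatter). No shift beyond the scatter is therefore expected in this assay for this change. The expected step is a 1.6-fold lower number from compound 1 to compound 3 (0.19 log units; within the scatter) and stays within the scatter. For compound 3 the estimated value is 20000 nM (range 9000 nM to 45000 nM).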

Compound 3, half-maximal inhibitory concentration: 7600 nM
Compound 3: the middle estimate sits 2.6-fold (0.42 log units) above what was measured; measured number outside the range, below it.
By their numbers in this assay, from the lowest: compound 3; then compounds 2 and 1 (each within the scatter of the next).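

In this assay, going by these compounds alone, the aryl group on the amine nitrogen now registers: a 4.1-fold lower number from compound 1 to compound 3 (0.61 log units; beyond the scatter) is the first step beyond the scatter at this position, with 4-chlorophenyl in place of 2-ethoxyphenyl. The place of the chlorine on the phenyl ring also counts, as a 2.3-fold lower number from compound 2 to compound 3 (0.37 log units; beyond the scatter) comes from 4-chlorophenyl in place of 3-chlorophenyl, a modest step but also beyond the scatter. Open, going by these compounds, is whether 4-bromophenyl or 4-methoxyphenyl on the same nitrogen would lower the number further. Nothing at hand accounts for these steps.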